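Swapping neopentyl for tert-butyl on a second core

The compounds below may be only part of what the source reports. "The series", "measured", "known", "first", "only" and "open" are said of these compounds alone.

Four compounds fall into two pairs. Compound 1 `CC(C)(C)[C@@H](O)C(=O)N1C[C@@H]2C[C@@H]2[C@H]1C(=O)NCc1cc(Cl)ccc1-n1cnnn1` and compound 2 `CC(C)(C)C[C@@H](O)C(=O)N1C[C@@H]2C[C@@H]2[C@H]1C(=O)NCc1cc(Cl)ccc1-n1cnnn1` share one core; compound 3 `CC(C)(C)C[C@@H](O)C(=O)N1[C@@H]2C[C@@H]2C[C@H]1C(=O)NCc1cc(Cl)ccc1-n1cnnn1` and compound 4 `CC(C)(C)[C@@H](O)C(=O)N1[C@@H]2C[C@@H]2C[C@H]1C(=O)NCc1cc(Cl)ccc1-n1cnnn1` share another. Compound 3 has the same atoms as compound 2 joined differently, and the difference between the two cores is not broken down here.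

In an ADME assay on liver for metabolic stability, with Liver microsome (Homo sapiens) as the target, read by LC-MS, using microsomes (on this read-out higher numbers stand for fast clearance and lower numbers for slow clearance), compound 2 gives 20 mL.min-1.g-1. In this assay compound 1 gives < 15 mL.min-1.g-1, which is a limit of the assay rather than a number. The change from compound 2 to compound 1 is tert-butyl in place of neopentyl on a saturated chain carbon bound to a carbonyl carbon and an oxygen on a saturated carbon, and it gave an at least 1.3-fold lower number from compound 2 to compound 1 (0.12 log units; that floor lies within the scatter). As far as these compounds go, that step rests on (the limit of < 15 mL.min-1.g-1 in this assay, at which 1 of the 3 values shown sits), so its true size stays open. In this assay compound 3 gives 71 mL.min-1.g-1, the highest of the two numbers and well apart from compound 2.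

The change from compound 3 to compound 4 is the same kind of change, (tert-butyl in place of neopentyl on a saturated chain carbon bound to a carbonyl carbon and an oxygen on a saturated carbon), made on the other core. One expects it to lower the number again, since compound 3 starts at 71 mL.min-1.g-1, well apart from compound 2, and so has room to fall. One therefore estimates for compound 4 a step of a 1.8-fold lower number from compound 3 to compound 4 (0.25 log units; within the scatter). For compound 4 one expects 40 mL.min-1.g-1, with a range from 15 mL.min-1.g-1 to 90 mL.min-1.g-1.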

Compound 4, intrinsic clearance in microsomes: 54 mL.min-1.g-1
Beside the measured number, compound 4's estimate is 1.4-fold (0.13 log units) below it, and the stated range covers the measured number.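

On the core of compound 3, tert-butyl in place of neopentyl gave a 1.3-fold lower number from compound 3 to compound 4 (0.12 log units; within the scatter) in this assay, so the two compounds cannot be told apart on this read-out. The change points the same way on both cores, but this does not show that it carries over at a fixed size, nor that its size depends on the core, and the comparison stands as follows: the same change on two cores in this assay, an at least 1.3-fold lower number (0.12 log units; that floor lies within the scatter) from compound 2 to compound 1 and a 1.3-fold lower number (0.12 log units; within the scatter) from compound 3 to compound 4; the limit leaves it open whether they differ The step on the core of compound 1 has only a floor and no measured size, since compound 1 sits at a limit of the assay rather than at a number: the limit of < 15 mL.min-1.g-1 in this assay, at which 1 of the 4 values shown sits.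

The compounds shown leave open how other groups would read on either core on a saturated chain carbon bound to a carbonyl carbon and an oxygen on a saturated carbon, for example isopropyl, cyclohexyl or a chain longer than neopentyl. They also leave open whether an amine in place of that oxygen would fit the same picture, and whether anything seen in this assay would hold in a read-out from another species or another test system.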